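This account rests on a few compounds, and the source may have more. Where it says the series, first, only, none or still open, it means among the compounds named here.

Among the measured compounds shown here, in a functional assay on BaF3 cells (Mus musculus) for inhibition, read by CCK-8 assay, with a stated time of 72 h (on this read-out higher numbers stand for weaker inhibition of growth and lower numbers for stronger inhibition of growth), compound 1 (`Cc1ccc(NC(=O)Nc2ccc(Oc3cc(/N=C/N(C)C)ncn3)cc2)cc1C(F)(F)F`) gives 6610 nM, the higher of the two numbers measured so far and therefore the weaker inhibition of growth. Compound 2 (`CC(=O)Nc1cc(Oc2ccc(NC(=O)Nc3cc(-n4cnc(C)c4)cc(C(F)(F)F)c3)cc2)ncn1`) gives 1320 nM, a lower number by a margin beyond the usual scatter, although it differs from compound 1 in more than one place. Compound 3 (`Cc1ccc(NC(=O)Nc2ccc(Oc3cc(NCCN)ncn3)cc2)cc1C(F)(F)F`) keeps the rest of compound 1 and exchanges one group on an aromatic carbon: a group of 4 heavy atoms (2 carbon, 2 nitrogen; no ring) in place of a group of 5 heavy atoms (3 carbon, 2 nitrogen; no ring), on an aromatic carbon. For the measured compounds named here, no measured pair shows this exchange alone, so any expectation here is loose. Since compound 1 already gives 6610 nM, the higher of the two numbers, a modest move toward a lower number seems likelier than a further rise. The expected change is a 2.2-fold lower number from compound 1 to compound 3 (0.34 log units; beyond the scatter). For compound 3 the estimated value is 3000 nM, with an expected range from 900 nM to 9000 nM.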

Compound 3, concentration for 50% growth inhibition: > 10000 nM
Compound 3: a limit, no number (the forecaster's own chance of this, stated with the estimate: 10%); middle value at least 3.3-fold (0.52 log units) from the limit.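

In this assay compound 3 gives > 10000 nM which is a limit of the assay and not a number: the limit of > 10000 nM in this assay, at which 1 of the 3 values shown sits.

Exchanging the group on this aromatic carbon for (2-aminoethyl)amino gives an at least 1.5-fold higher number from compound 1 to compound 3 (0.17 log units; that floor lies within the scatter) and so this change at this position brings no lower number. From the compounds shown here alone, only a floor can be given for this step, so its real size stays unknown.

The compounds shown leave open whether a longer chain such as 3-aminopropylamino, a ring amine such as morpholine or a carboxylic acid on this same aromatic carbon would give a lower number than compound 1. Compound 2 also carries a different group here, but it differs from compound 1 in more than one place and cannot settle the effect of this position alone.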